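The source may hold more compounds than are shown below. What is called first, only, known or untested is meant among the compounds shown, and "the series" means these compounds.

In an ADME assay on HEp-2 cells (Homo sapiens) for cytotoxicity, read by MTT assay, with a stated time of 72 h (on this read-out lower numbers stand for stronger inhibition and higher numbers for weaker inhibition), compound 1 `COc1cc(C2=C(c3cc(C)c(OC)c(C)c3)C(O)CC2=O)cc(OC)c1OC` gives > 100 ug/mL, which is a limit of the assay and not a number. Compound 2 `COc1cc(C2=C(c3ccccc3)C(O[SiH2]C(C)(C)C)CC2=O)cc(OC)c1OC` gives > 100 ug/mL, which is also a limit. Compound 2 therefore stands at the limit of > 100 ug/mL in this assay, at which 2 of the 2 values shown sit, so no exact potency is known for it.

Compound 3 `COc1cc(C2=C(c3cc(C)c(OC)c(C)c3)C(O[SiH2]C(C)(C)C)CC2=O)cc(OC)c1OC` keeps the rest of compound 2 but has 4-methoxy-3,5-dimethylphenyl in place of phenyl on a double-bonded ring carbon. Within the data shown here, no measured pair of compounds shows the size of this change directly. Compound 1 does carry the same 4-methoxy-3,5-dimethylphenyl group, and with it shows only the limit of > 100 ug/mL. On that basis, no step beyond the usual scatter is expected in this assay, in either direction. The estimated step of a number no higher from compound 2 to compound 3 (the limit leaves the size open) is correspondingly small. For compound 3 the estimate is 100 ug/mL, with an expected range from 50 ug/mL to 200 ug/mL, and the measurement may well come back as a limit again.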

Compound 3, half-maximal inhibitory concentration: 26 ug/mL
Compound 3: the middle estimate sits 3.8-fold (0.59 log units) above what was measured; measured number below the stated range.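

The double-bonded ring carbon is not a silent place in this series: putting 4-methoxy-3,5-dimethylphenyl in place of phenyl there, with the rest of the molecule kept, gives an at least 3.8-fold lower number from compound 2 to compound 3 (0.58 log units; beyond the scatter). That group is not enough on its own, since compound 1 carries it as well, and adding the group of 5 heavy atoms (4 carbon, 1 silicon) in place of the hydrogen on the oxygen gives an at least 3.8-fold lower number from compound 1 to compound 3 (0.58 log units; beyond the scatter). Among these three compounds, only the one carrying both groups gives an exact number in this assay, while the other two remain at a limit: the limit of > 100 ug/mL in this assay, at which 2 of the 3 values shown sit.

As far as these compounds go, both steps are minimum sizes, so how much each change truly contributes remains unknown, as does whether the two changes act independently or only in combination. The compounds shown also cannot separate the methoxy group from the two methyl groups of 4-methoxy-3,5-dimethylphenyl, and they leave open what a single methyl group, an amine or a carboxylic acid on the aromatic ring in place of that pattern would do, or a longer chain on the oxygen.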